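Chain-to-benzyl switch at the aryl ether of the lactam core

This account rests on a few compounds, and the source may have more. Where it says the series, first, only, none or still open, it means among the compounds named here.

Measured so far:
- compound 1 `CCCCCCOc1ccc2c(c1)C(=O)NCCO2`: 47.3 mg/kg
- compound 2 `CCCCCCCOc1ccc2c(c1)C(=O)NCCO2`: 19 mg/kg

In a functional assay on the whole organism with Mus musculus as the target, in the maximal electroshock model, with stated times of 30 min and 4 h (a lower number here means that less compound is needed, a higher number that more compound is needed for the effect), compound 2 stands lowest of the two numbers; its nearest neighbour is compound 1, which is one step away. That step, a 2.5-fold lower number from compound 1 to compound 2 (0.40 log units; beyond the scatter), is the only measured one in the series and it concerns chain lengthening alone.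

Compound 3 `O=C1NCCOc2ccc(OCc3ccccc3)cc21` has not been tested. It differs from compound 2 as follows: phenyl in place of hexyl on a saturated chain carbon bound to an oxygen on an aromatic ring. Among the measured compounds shown here, no measured step in this assay speaks to an aromatic ring entering at this position; the chain-lengthening step tells nothing directly about it, and compound 1 shows only that a shorter chain gave a higher number.

For the measured compounds named here, with no step that bears on the change, the expectation for compound 3 in this assay is close to compound 2, with wide uncertainty, as an estimated step of a 1.8-fold higher number from compound 2 to compound 3 (0.27 log units; within the scatter). Compound 3 is therefore estimated at 35 mg/kg, with a range from 12 mg/kg to 100 mg/kg.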

Compound 3, dose for half-maximal effect: 73.1 mg/kg
For compound 3 the middle estimate is 2.1-fold (0.32 log units) below the measured one; low and high end bracket the measured number.
By their numbers in this assay, from the lowest: compound 2; then compounds 1 and 3 (each within the scatter of the next).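

In this assay, phenyl in place of hexyl on a saturated chain carbon bound to an oxygen on an aromatic ring gives a 3.8-fold higher number from compound 2 to compound 3 (0.59 log units; beyond the scatter), so at this place an aromatic ring of the same heavy-atom count as the hexyl does not hold the level reached with the longer chain. Phenyl in place of pentyl gives a 1.5-fold higher number from compound 1 to compound 3 (0.19 log units; within the scatter), so the two numbers cannot be separated and the gain seen on chain lengthening is lost with this change. No evidence on hand accounts for the difference between phenyl and hexyl here.

A cyclohexyl in place of the phenyl would separate the effect of a ring as such from that of an aromatic ring. On these data alone, whether an octyl chain would lower the number further, or whether a chloro or methoxy group on the phenyl would recover the lost ground, stays open.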